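Swapping a Benzofuran for a Thiophene on a Shared Core

This account rests on a few compounds, and the source may have more. Where it says the series, first, only, none or still open, it means among the compounds named here.

Compound 1 `Cc1ncnc2c1c(-c1cc3ccccc3o1)cn2[C@@H]1O[C@H](CO)[C@@H](O)[C@H]1O` and compound 2 `Cc1nc(N)c2c(-c3cc4ccccc4o3)cn([C@@H]3O[C@H](CO)[C@@H](O)[C@H]3O)c2n1` share a sugar-bearing core; the difference between the two cores is not broken down here. In a functional assay on HeLa S3 cells (Homo sapiens) for antiproliferative activity, read by XTT assay, with a stated time of 72 h (on this read-out lower numbers stand for stronger inhibition and higher numbers for weaker inhibition), compound 1 gives only a limit of the assay, > 20000 nM. Compound 2 likewise gives only a limit, > 20000 nM. Compound 3 `Cc1ncnc2c1c(-c1ccsc1)cn2[C@@H]1O[C@H](CO)[C@@H](O)[C@H]1O` carries the change thiophen-3-yl in place of 1-benzofuran-2-yl on an aromatic carbon and in this assay gives 14300 nM, a step of an at least 1.3-fold lower number from compound 1 to compound 3 (0.14 log units; that floor lies within the scatter). This measured step rests on a floor rather than a firm number because of the limit of > 20000 nM in this assay, at which 2 of the 3 values shown sit. Compound 4 `Cc1nc(N)c2c(-c3ccsc3)cn([C@@H]3O[C@H](CO)[C@@H](O)[C@H]3O)c2n1` carries the same change, (thiophen-3-yl in place of 1-benzofuran-2-yl on an aromatic carbon), on the core of compound 2. The expected step for compound 4 is an at least 1.3-fold lower number from compound 2 to compound 4 (0.12 log units; that floor lies within the scatter), resting on the similar move that compound 3 made from compound 1. Compound 4 is therefore estimated at 15000 nM in this assay.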

Compound 4, half-maximal inhibitory concentration: > 20000 nM
Compound 4: a limit, no number (the forecaster's own chance of this, stated with the estimate: 50%); at least 1.3-fold (0.12 log units) between middle value and limit.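

No step can be read from compound 2 to compound 4, because both give only a limit: the limit of > 20000 nM in this assay, at which 3 of the 4 values shown sit. As far as these compounds go, what stays open is whether thiophen-3-yl in place of 1-benzofuran-2-yl changes the activity at all on either core.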